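Swapping the Sulfonyl Aryl Group on the Way to Compound 4

The source may report more compounds than this note shows. Statements on the series, on what has been measured and on what is new or still open speak of the compounds shown alone.

In an ADME assay on microsomes from liver (Homo sapiens) for metabolic stability, tested at 2.5 uM (a higher number here means faster removal of the compound, a lower number slower removal), compound 3 `O=S(=O)(c1ccc(F)c(F)c1)c1cnc2c(F)cccc2c1-c1cccc(F)c1` gives 1.28 mL/min, the second highest of the three numbers, within the scatter of compound 1 `O=S(=O)(c1ccc(F)c(F)c1)c1cnc2c(F)cccc2c1-c1ccccc1F` at 1.39 mL/min and well apart from compound 2 `O=S(=O)(c1ccc(F)c(F)c1)c1cnc2c(F)cccc2c1-c1ccc(Cl)cc1` at 0.28 mL/min. Compound 4 `COc1ccc(S(=O)(=O)c2cnc3c(F)cccc3c2-c2cccc(F)c2)cc1` differs from compound 3 at the sulfonyl sulfur: 4-methoxyphenyl in place of 3,4-difluorophenyl on a sulfonyl sulfur. Every measured step instead alters the ring on the aromatic carbon: a 5.0-fold lower number from compound 1 to compound 2 (0.70 log units; beyond the scatter), a 4.6-fold higher number from compound 2 to compound 3 (0.66 log units; beyond the scatter) and a 1.1-fold lower number from compound 1 to compound 3 (0.04 log units; within the scatter). Among the compounds with values here, none of them touches the sulfonyl group, so no measured step bears on this change, and the direction of any effect cannot be read from the data. Compound 4 is therefore expected to show a step of a 1.0-fold higher number from compound 3 to compound 4 (0.01 log units; within the scatter) that could go either way, and its estimate is 1.3 mL/min, ranging from 0.4 mL/min to 4 mL/min.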

Compound 4, intrinsic clearance in a liver preparation (reported as CLH), per the amount of preparation that the assay uses: 3.03 mL/min
Estimate against measurement, compound 4: 2.3-fold (0.37 log units) below, within the range that was stated.
By their numbers in this assay, from the lowest: compound 2; then compounds 3 and 1 (each within the scatter of the next); then compound 4.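

In this assay there is a 2.4-fold higher number from compound 3 to compound 4 (0.37 log units; beyond the scatter) when 4-methoxyphenyl replaces 3,4-difluorophenyl on a sulfonyl sulfur. Within the data shown here, this position, which no earlier step touched, therefore also moves the number, here toward faster removal. Nothing available accounts for the shift.

This single swap cannot separate the arrival of the methoxy group from the loss of the fluorines, and it leaves open whether the same change would hold with the 4-chlorophenyl of compound 2 on the shared core. From the compounds shown here alone, how an amine or a carboxylic acid on the sulfonyl aryl ring would fare also remains open.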